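Adding a Second Chloro to a Thiazole Amide Inhibitor

A few compounds are considered here, and "the series" means these few. Any claim that something is new, unique, unknown or untested is made for them only; others in the source may bear on it.

Three compounds share a core in which an aromatic amide is joined to a thiazole that carries a benzyl arm. Compound 1 `Cc1ccc(C(=O)Nc2ncc(Cc3cccc(C(F)(F)F)c3)s2)cc1C` differs from the others in both its amide part and its benzyl arm; in an assay on microsomes for inhibition of acyl-CoA desaturase 1 (Mus musculus), with a stated time of 60 min (on this read-out higher numbers stand for weaker inhibition and lower numbers for stronger inhibition), compound 1 gives 8220 nM. Compound 2 `COc1ccc(C(=O)Nc2ncc(Cc3cccc(Cl)c3)s2)cc1OCCO` carries a 3-chlorobenzyl arm, and in this assay compound 2 gives 1 nM. Compound 3 `COc1ccc(C(=O)Nc2ncc(Cc3cc(C(F)(F)F)cc(C(F)(F)F)c3)s2)cc1OCCO` carries a bis(trifluoromethyl)benzyl arm, and in this assay compound 3 gives 0.6 nM.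

Of these three numbers, compound 2 has the second highest: its number lies within the scatter of that of compound 3, while that of compound 1 lies far beyond the scatter, much higher.

Compound 4 `COc1ccc(C(=O)Nc2ncc(Cc3ccc(Cl)c(Cl)c3)s2)cc1OCCO` is not yet measured. It differs from compound 2 in one place: chloro in place of hydrogen on an aromatic carbon. Among the compounds with values here, the only comparison at hand, compound 2 against compound 3, shows that a heavier benzyl arm keeps a low number, so no step beyond the scatter is expected from compound 2 to compound 4, perhaps a slightly lower number at most; the expected step is a 1.3-fold lower number from compound 2 to compound 4 (0.10 log units; within the scatter). For compound 4 the estimate in this assay is 0.8 nM, within a range from 0.3 nM to 2.5 nM.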

Compound 4, half-maximal inhibitory concentration: 0.8 nM
Beside the measured number, compound 4's estimate shows no gap at the digits printed; the measured number falls inside the stated range.
By their numbers in this assay, from the lowest: compounds 3, 4 and 2 (each within the scatter of the next); then compound 1.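

Among the compounds shown, this is the only pair that differs in one place, so the effect of a single change can be read directly: going from 3-chlorobenzyl to 3,4-dichlorobenzyl, this assay shows a 1.3-fold lower number from compound 2 to compound 4 (0.10 log units; within the scatter). The position, ortho to a chloro group and para to a large group, therefore takes a chloro in place of hydrogen with no change that can be told apart from the scatter of repeated measurements. Nothing at hand explains why the number stays where it is.

Going by these compounds, whether an amine, a carboxylic acid or a longer chain at this same position would also keep the number so low remains open. So does what a lone chloro at this position would give, with the 3-chloro replaced by hydrogen.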